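This account rests on a few compounds, and the source may have more. Where it says the series, first, only, none or still open, it means among the compounds named here.

Three compounds built on one shared core were tested in a physicochemical assay for solubility, read by nephelometry, measured as kinetic solubility, with a stated time of 30 min; a higher number here means a more soluble compound, a lower number a less soluble compound. Compound 1 `CC(C)(O)CN1CCC(Oc2ccc([C@H]3CC[C@]4(CC3)OOC3(O4)C4CC5CC(C4)CC3C5)cc2)CC1` carries a 1-(2-hydroxy-2-methylpropyl)piperidin-4-yl group on an oxygen on an aromatic ring, and in this assay compound 1 gives 1.6 ug/mL. Compound 2 `c1cc([C@H]2CC[C@]3(CC2)OOC2(O3)C3CC4CC(C3)CC2C4)ccc1OCCC1CCNCC1` has a 2-(piperidin-4-yl)ethyl group in that place. For compound 2 the method reports only a limit, > 100 ug/mL. Compound 3 `c1cc([C@H]2CC[C@]3(CC2)OOC2(O3)C3CC4CC(C3)CC2C4)ccc1OC1CCNCC1` has a plain piperidin-4-yl group there. For compound 3 the method likewise reports only a limit, > 100 ug/mL. Compound 3 thus stands at the limit of > 100 ug/mL in this assay, at which 2 of the 3 values shown sit, together with one other value, and no exact number is known for it. Among the compounds with values here, the step of an at least 62-fold higher number from compound 1 to compound 3 (1.79 log units; beyond the scatter) is the one readable change, while a step that the two limits leave unreadable from compound 2 to compound 3.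

Compound 4 `NCCCCOc1ccc([C@H]2CC[C@]3(CC2)OOC2(O3)C3CC4CC(C3)CC2C4)cc1` differs from compound 3 by 4-aminobutyl in place of piperidin-4-yl on an oxygen on an aromatic ring. Within the data shown here, both groups keep a single amine nitrogen as donor and acceptor, and no measured step separates a ring amine from a chain amine, since the step from compound 2 to compound 3 is unreadable. The expectation is therefore no change beyond the scatter, that is a number no higher from compound 3 to compound 4 (the limit leaves the size open). Compound 4 is estimated at 100 ug/mL, in the range 40 ug/mL to 200 ug/mL, most likely again reported as a limit.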

Compound 4, solubility: 50 ug/mL
For compound 4 the middle estimate is 2.0-fold (0.30 log units) above the measured one; measured number inside the range.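

In this assay, within the data shown here, compound 4 gives 50 ug/mL, the first exact number for a compound in this set whose amine nitrogen carries no added group. Setting 4-aminobutyl in place of piperidin-4-yl gives an at least 2.0-fold lower number from compound 3 to compound 4 (0.30 log units; that floor lies within the scatter), and the other comparison gives an at least 2.0-fold lower number from compound 2 to compound 4 (0.30 log units; that floor lies within the scatter); neither floor shows a real drop, and the true size of both steps stays unknown, as compound 2 and compound 3 are reported only as limits: the limit of > 100 ug/mL in this assay, at which 2 of the 4 values shown sit. The third comparison gives a 31-fold higher number from compound 1 to compound 4 (1.49 log units; beyond the scatter), so a group with no ring can still stand far from compound 1.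

From the compounds shown here alone, how the number moves with chain length on the same oxygen remains open, for example with 3-aminopropyl or 6-aminohexyl. Also open, going by these compounds, is what a carboxylic acid at the end of the chain, in place of the amine, would give.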